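A few compounds are considered here, and "the series" means these few. Any claim that something is new, unique, unknown or untested is made for them only; others in the source may bear on it.

Results so far in an ADME assay on CCRF-CEM cells (Homo sapiens) for cytotoxicity, read by MTT assay, with a stated time of 72 h (a lower number here means that less compound is tolerated, a higher number that more compound is tolerated), are these:

- compound 1 `CC(=O)c1c(O)c(C(C)=O)c(O)c(C(CCc2ccccc2)c2c(O)c(C(C)=O)c(O)c(C(C)=O)c2O)c1O` gives "not determined" (no result reported)
- compound 2 `CC(C)CC(=O)c1c(O)c(C(=O)CC(C)C)c(O)c(C(c2ccc(OCc3ccccc3)cc2)c2c(O)c(C(=O)CC(C)C)c(O)c(C(=O)CC(C)C)c2O)c1O` gives 24000 nM

Compound 1 stands without a number, so it offers no starting point on this scale. The compound of interest here is the unmeasured compound 3 `CC(=O)c1c(O)c(C(C)=O)c(O)c(C(c2ccco2)c2c(O)c(C(C)=O)c(O)c(C(C)=O)c2O)c1O`, which keeps the core of compound 1 and alters one group. That alteration is furan-2-yl in place of phenethyl on a saturated chain carbon bound to two aromatic carbons and it puts furan-2-yl in place of phenethyl on a saturated chain carbon bound to two aromatic carbons.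

For the measured compounds named here, no two measured compounds differ in only one place, so the data contain no measured example of what such a swap does. Going by the values given here, the only number available comes from compound 2 at 24000 nM and it serves as a rough anchor, not as a true comparison. In this assay the step from compound 1 is expected to be small, with none beyond the usual scatter and no direction favoured. Compound 3 is estimated at 30000 nM and is expected to fall between 10000 nM and 90000 nM.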

Compound 3, half-maximal cytotoxic concentration: 61200 nM
Compound 3: middle estimate off by 2.0-fold (0.31 log units), on the low side; low and high end bracket the measured number.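

Compound 1 has no number to set against compound 3, and compound 2 differs from compound 3 in more than one place, so no step can be read. As far as these compounds go, what furan-2-yl in place of phenethyl does in this assay stays open. No evidence on hand bears on the result for compound 3.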